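Cytotoxicity of a 4-methylphenyl analogue in Vero cells

The compounds below may be only part of what the source reports. "The series", "measured", "known", "first", "only" and "open" are said of these compounds alone.

In an ADME assay on Vero cells (Chlorocebus sabaeus) for cytotoxicity, read by XTT assay, with a stated time of 72 h (a lower number here means that less compound is tolerated, a higher number that more compound is tolerated), the shared core of compound 1 `CC1=C(C(=O)Nc2ccccc2Cl)C(c2ccccc2Cl)NC(=S)N1` sits at the limit of the assay, compound 1 giving > 100000 nM. Compound 2 `CC1=C(C(=O)Nc2ccccc2Cl)C(c2ccccc2Cl)NC(=O)N1` is reported in this assay only as "non-toxic" (no number reported), without a number. Compound 3 `CC1=C(C(=O)Nc2ccccc2Cl)C(c2cccc(Br)c2)NC(=O)N1` likewise reaches only the limit of this assay, compound 3 giving > 100000 nM. Compound 3 therefore stands where most of the set stands, at the limit of > 100000 nM in this assay, at which 2 of the 3 values shown sit. Compound 4 `CC1=C(C(=O)Nc2ccccc2Cl)C(c2ccc(C)cc2)NC(=O)N1` differs from compound 3 by 4-methylphenyl in place of 3-bromophenyl on a saturated ring carbon, a 4-methylphenyl in place of 3-bromophenyl on a saturated ring carbon. Within the data shown here, no measured step between neighbouring compounds in this assay is available, so no direction beyond the scatter is indicated. Compound 4 is expected to remain at the limit too, with an estimated 150000 nM spanning 60000 nM to 400000 nM. The expected step that the limit leaves unreadable from compound 3 to compound 4 lies within the scatter.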

Compound 4, half-maximal cytotoxic concentration: > 100000 nM
Compound 4 gave a limit, no number (the forecaster's own chance of this, stated with the estimate: 80%); the middle value does not contradict the limit.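

Among these compounds, compound 3 and compound 4 both end at a limit in this assay, so no step between them can be read: the limit of > 100000 nM in this assay, at which 3 of the 4 values shown sit. The compounds shown leave open at what concentration, if any, the shared core harms these cells.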